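The source may report more compounds than this note shows. Statements on the series, on what has been measured and on what is new or still open speak of the compounds shown alone.

In a physicochemical assay for solubility, read by HPLC (a higher number here means a more soluble compound, a lower number a less soluble compound), compound 3 `O=c1nc(N2CCN(CC3CCCCC3)CC2)sc2c([N+](=O)[O-])cc(C(F)(F)F)cc12` gives 9.07 ug/mL. Compound 2 `O=C(c1ccc(Cl)cc1)N1CCN(c2nc(=O)c3cc(C(F)(F)F)cc([N+](=O)[O-])c3s2)CC1` gives 5.19 ug/mL, within the scatter of that number, so the two share the top of the set. Compound 1 `O=C(CC1CCCCC1)N1CCN(c2nc(=O)c3cc(C(F)(F)F)cc([N+](=O)[O-])c3s2)CC1` gives 0.12 ug/mL, well under both. Compound 4 `CC(C)(C)C(=O)N1CCN(c2nc(=O)c3cc(C(F)(F)F)cc([N+](=O)[O-])c3s2)CC1` puts (tert-butyl)carbonyl in place of cyclohexylmethyl on an amine nitrogen in a ring. Two measured steps run the opposite way, removing a carbonyl-bearing group in favour of cyclohexylmethyl. The step of a 76-fold higher number from compound 1 to compound 3 (1.88 log units; beyond the scatter) is large, while the step of a 1.7-fold higher number from compound 2 to compound 3 (0.24 log units; within the scatter) stays within the scatter. These two disagree, so a middling outcome seems the fairest expectation. In this assay, the expected step is a 2.3-fold lower number from compound 3 to compound 4 (0.36 log units; beyond the scatter), a modest fall. Compound 4 is estimated at 4 ug/mL, with an expected range of 0.6 ug/mL to 25 ug/mL.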

Compound 4, solubility: 5.87 ug/mL
For compound 4 the middle estimate is 1.5-fold (0.17 log units) below the measured one; measured number inside the range.
By their numbers in this assay, from the lowest: compound 1; then compounds 2, 4 and 3 (each within the scatter of the next).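

In this assay, replacing cyclohexylmethyl on the ring nitrogen with (tert-butyl)carbonyl gives only a small step (a 1.5-fold lower number from compound 3 to compound 4 (0.19 log units; within the scatter)), so a carbonyl-bearing group here can match the cyclohexylmethyl compound. What sits on the carbonyl carbon matters more: tert-butyl and 4-chlorophenyl are indistinguishable (a 1.1-fold higher number from compound 2 to compound 4 (0.05 log units; within the scatter)), whereas tert-butyl and cyclohexylmethyl are far apart (a 49-fold higher number from compound 1 to compound 4 (1.69 log units; beyond the scatter)). Compound 1 alone is low, and compounds 2 and 4 go against any rule that the carbonyl itself lowers the number. Going by these compounds, whether a carbonyl carrying a simple amine or a carboxylic acid chain would stay at this level remains open. No measurement offered here explains these differences.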